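The compounds below may be only part of what the source reports. "The series", "measured", "known", "first", "only" and "open" are said of these compounds alone.

Measured so far:
Compound 1 `Nc1cc(N)c2nc(-c3ccccc3)c(Oc3ccc(Cl)c(Cl)c3)nc2c1` — in a functional assay on TK-10 cells (Homo sapiens) for inhibition, read by sulforhodamine B assay, with a stated time of 48 h (a lower number here means that less compound is tolerated, a higher number that more compound is tolerated), compound 1 gives < 100000 nM, which is a limit of the assay and not a number.
Compound 2 `CCOC(=O)[C@H](CCC(=O)O)NC(=O)c1ccc(CNc2nc3cc(N)cc(N)c3nc2-c2ccccc2)cc1` — in this assay compound 2 gives < 100000 nM, likewise a limit of the assay.

Within the data shown here, compound 1 therefore stands only at a limit in this assay, and the one further value shown is a limit as well (the limit of < 100000 nM in this assay, at which 2 of the 2 values shown sit). Among the measured compounds shown here, the two measured compounds do not differ in a single place, so no measured step exists between them; their two values show only that both sit at the same limit.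

Compound 3 `Nc1cc(N)c2nc(-c3ccccc3)c(Sc3ccc(Cl)c(Cl)c3)nc2c1` differs from compound 1 in one place: (3,4-dichlorophenyl)sulfanyl in place of 3,4-dichlorophenoxy on an aromatic carbon. For the measured compounds named here, no measured step guides this change. The step in this assay is expected to stay within the scatter, with no direction favoured, estimated as a step that the limit leaves unreadable from compound 1 to compound 3. Compound 3 is accordingly expected to give about 20000 nM in this assay, in the range 4000 nM to 90000 nM, with a real chance that only a limit is reported again.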

Compound 3, concentration lethal to 50% of the cells: 53700 nM
Compound 3: middle estimate off by 2.7-fold (0.43 log units), on the low side; the measured number falls inside the stated range.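

In this assay compound 1 gives < 100000 nM, a limit of the assay and not a number. Among these compounds, no step can therefore be read from compound 1 to compound 3, which gives 53700 nM. The compounds shown leave open whether (3,4-dichlorophenyl)sulfanyl in place of 3,4-dichlorophenoxy changes the value, and in which direction.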